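The source may report more compounds than this note shows. Statements on the series, on what has been measured and on what is new or still open speak of the compounds shown alone.

- Compound 1 `CCN1CCN(c2nc(C)nc3c2nc(-c2ccccc2Cl)n3C)CC1` gives 88%
- Compound 2 `Cc1nc(N2CCN(C)CC2)c2nc(-c3ccccc3Cl)n(CCO)c2n1` gives 99%

In an ADME assay (liver) for metabolic stability, with Liver microsome (Canis lupus familiaris) as the target, read by LC-MS, using microsomes, with a stated time of 30 min, tested at 4 uM (a lower number here means that less of the compound is left, a higher number that more of the compound is left), compound 1 gives 88% as the lower of the two numbers, and compound 2 gives 99% with a gap beyond the usual scatter. Much of compound 1 therefore survives the incubation, although it stands at the bottom of this very short series.

Compound 3 `CCN1CCN(c2nc(C)nc3c2nc(-c2ccccc2Cl)n3CCOC)CC1` keeps the core of compound 1 and differs from it by methoxymethyl in place of hydrogen on a saturated chain carbon bound to an aromatic nitrogen as methoxymethyl in place of hydrogen on a saturated chain carbon bound to an aromatic nitrogen. The same difference reads as methyl to 2-methoxyethyl.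

Among the measured compounds shown here, no step between measured compounds that differ in one place is available, so the size of this change in this assay has no direct precedent. With compound 1 at 88% there is little room for a rise, so a modest fall is the more likely direction, though a result within the scatter would not surprise. The expected change is a number 6 percentage points lower from compound 1 to compound 3 (within the scatter) and it remains an uncertain one. For compound 3 the estimate is 82% with a range from 65% to 96% expected to hold the measurement.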

Compound 3, percent of the compound remaining: 86%
Estimate against measurement, compound 3: 4 percentage points below; the range from low to high includes it.
By their numbers in this assay, from the lowest: compounds 3 and 1 (each within the scatter of the next); then compound 2.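

Among the compounds shown here, at this position, the first step that can be read in this assay is the change from methyl to 2-methoxyethyl, which gives a number 2 percentage points lower from compound 1 to compound 3 (within the scatter). Adding methoxymethyl, with its 3 heavy atoms and no ring, on a saturated chain carbon bound to an aromatic nitrogen therefore leaves a number that cannot be told apart from that of compound 1 in this assay. Nothing at hand bears on why the two numbers stay so close.

For the compounds shown here, compound 2 differs from both compound 1 and compound 3 in more than one place, so it adds no step for this position and the part played by its own chain stays unresolved. The compounds shown also leave open whether the same position would accept a longer chain, an amine or a carboxylic acid with as little effect on the percentage remaining in this assay.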